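This account rests on a few compounds, and the source may have more. Where it says the series, first, only, none or still open, it means among the compounds named here.

Compound 1 `CCCCC1CCC(OC(=O)N[C@@H](CC(C)C)C(=O)N[C@H](C=O)C[C@@H]2CCNC2=O)CC1` gives 63300 nM in a toxicity assay on Huh-7 cells (Homo sapiens) for cytotoxicity; a higher number here means that more compound is tolerated, a lower number that less compound is tolerated. Compound 2 `CC(C)C[C@H](NC(=O)OC1CCC(F)(F)CC1)C(=O)N[C@H](C=O)C[C@@H]1CCNC1=O` reaches only the limit of this assay, reported as > 100000 nM. Compound 3 `CC(C)C[C@H](NC(=O)OCC1CCC(F)(F)CC1)C(=O)N[C@H](C=O)C[C@@H]1CCNC1=O` likewise reaches only the limit of this assay, reported as > 100000 nM. Compound 3 thus stands at the limit of > 100000 nM in this assay, at which 2 of the 3 values shown sit, with no number of its own. The change to compound 4 `CC(C)C[C@H](NC(=O)OC1CCCCC1)C(=O)N[C@H](C=O)C[C@@H]1CCNC1=O` is cyclohexyl in place of (4,4-difluorocyclohexyl)methyl on an oxygen next to a carbonyl group. For the measured compounds named here, no measured step covers this change directly: the step that the two limits leave unreadable from compound 2 to compound 3 gives no size, while an at least 1.5-fold higher number from compound 1 to compound 2 (0.19 log units; that floor lies within the scatter) and an at least 1.5-fold higher number from compound 1 to compound 3 (0.19 log units; that floor lies within the scatter) both stay within the scatter. Compound 4 is therefore expected to show no step beyond the scatter, an at least 1.1-fold lower number from compound 3 to compound 4 (0.04 log units; that floor lies within the scatter). Compound 4 is estimated at 90000 nM, between 40000 nM and 200000 nM, with a real chance that this assay again reports only a limit.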

Compound 4, half-maximal cytotoxic concentration: > 100000 nM
Compound 4: no number, only a limit; the forecaster's own chance of this, stated with the estimate: 50%; middle value at least 1.1-fold (0.04 log units) away from the limit.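

Without any fluorine, the cyclohexyl group on the oxygen still leaves compound 4 with only a limit in this assay: the limit of > 100000 nM in this assay, at which 3 of the 4 values shown sit. For the compounds shown here, the one readable step is an at least 1.5-fold higher number from compound 1 to compound 4 (0.19 log units; that floor lies within the scatter), with hydrogen in place of butyl on a saturated ring carbon. The steps from compound 2 and compound 3 to compound 4 cannot be read, as both ends of each are limits.

On these data alone, the true values of compound 2, compound 3 and compound 4 remain open. Also open, as far as these compounds go, is whether a longer chain than butyl, or an amine, on the ring would give a number.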